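Swapping the nonyl chain for a bromophenyl ring

The compounds below may be only part of what the source reports. "The series", "measured", "known", "first", "only" and "open" are said of these compounds alone.

Of the compounds shown here, three have been measured in a functional assay on SK-N-SH cells (Homo sapiens) for inhibition, read by MTT assay; a higher number here means a weaker inhibitor, a lower number a stronger inhibitor. Compound 1 `O=C(CN1CCC(Cc2ccccc2)CC1)Nc1ccc(C(=O)/C=C/c2cn(Cc3ccc(Br)cc3)nn2)cc1` gives 42900 nM, compound 2 `CCCCCCCCn1cc(/C=C/C(=O)c2ccc(N)cc2)nn1` gives 28800 nM, and compound 3 `CCCCCCCCCCn1cc(/C=C/C(=O)c2ccc(NC(=O)CN3CCN(c4ccccc4)CC3)cc2)nn1` gives 39500 nM. The number of compound 3 is the second highest of the three, yet its gaps to compound 1 and to compound 2 both fall within the scatter, so the three cannot be told apart. Compound 4 `O=C(CN1CCN(c2ccccc2)CC1)Nc1ccc(C(=O)/C=C/c2cn(Cc3ccc(Br)cc3)nn2)cc1` differs from compound 3 by 4-bromophenyl in place of nonyl on a saturated chain carbon bound to an aromatic nitrogen. Because compound 1 with 4-bromophenyl at the same place gives 42900 nM, the step from compound 3 to compound 4 in this assay is expected to be a 1.0-fold higher number from compound 3 to compound 4 (0.01 log units; within the scatter), nothing beyond the scatter. Compound 4 is therefore estimated at 40000 nM, within a range of 20000 nM to 80000 nM.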

Compound 4, half-maximal inhibitory concentration: 72400 nM
Compound 4: middle estimate off by 1.8-fold (0.26 log units), on the low side; measured number inside the range.
By their numbers in this assay, from the lowest: compounds 2, 3, 1 and 4 (each within the scatter of the next, the first and the last beyond it).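

Among these compounds, the exchange gives the first direct comparison at this position: in this assay, 4-bromophenyl in place of nonyl gives a 1.8-fold higher number from compound 3 to compound 4 (0.26 log units; within the scatter) and so leaves the two compounds indistinguishable. On this single pair, an aromatic ring at this place reads the same as a saturated chain. No measurement shown offers an explanation for this step.

From the compounds shown here alone, it remains open whether a carboxylic acid or an amine at this place would shift the number beyond the scatter. Going by these compounds, it is also open whether the same exchange would read alike on the core of compound 1.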